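Working notes: compound 1 to compound 4

This account rests on a few compounds, and the source may have more. Where it says the series, first, only, none or still open, it means among the compounds named here.

Compound 1 (`C=C[C@@](C)(/C=C/c1ccc(OC)cc1)CCC=C(C)C`) has no measured position in the series. In a functional assay on NALM-6 cells (Homo sapiens) for cytotoxicity, with a stated time of 72 h (a higher number here means that more compound is needed for the effect, a lower number that less compound is needed), compound 1 reads > 43400 nM as a limit of the assay. Compound 2 (`C=C[C@@](C)(/C=C/c1ccc(O)cc1)CCCO`) reads > 43400 nM as a limit too. Compound 3 (`C=C[C@@](C)(/C=C/c1ccc(O)c(/C=C/C(N)=O)c1)CCC=C(C)C`) reads > 43400 nM as a further limit. Going by the values given here, the record so far is therefore the limit of > 43400 nM in this assay, at which 3 of the 3 values shown sit, and holds no number, so no step between measured compounds is available to size a change.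

The next compound is compound 4 (`C=C[C@@](C)(/C=C/c1ccc(Nc2ccc(F)cc2)cc1)CCC=C(C)C`). It differs from compound 1 by (4-fluorophenyl)amino in place of methoxy on an aromatic carbon and carries (4-fluorophenyl)amino in place of methoxy on an aromatic carbon, para to a large group. Among the compounds with values here, no measured compound carries this group, and the expectation rests on the structural change alone. The estimated change is an at least 2.4-fold lower number from compound 1 to compound 4 (0.38 log units; beyond the scatter) and is expected to point towards less compound being needed in this assay, with a real chance that only a limit is reported again. For compound 4 the expected value is 18000 nM on this estimate, with an estimated range from 5000 nM to 60000 nM as its bounds.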

Compound 4, half-maximal effective concentration: > 43400 nM
Compound 4 was reported as a limit; the forecaster's own chance of this, stated with the estimate: 45%; at least 2.4-fold (0.38 log units) between middle value and limit.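

In this assay compound 4 gives > 43400 nM, which is a limit of the assay. Compound 1 also has only a limit, so no step can be read between compound 1 and compound 4. The compounds shown leave open whether any change to the shared core yields a number rather than a limit: the limit of > 43400 nM in this assay, at which 4 of the 4 values shown sit.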